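Replacing 4-Fluorophenyl with Thiophen-2-yl on a Shared Core

The source may hold more compounds than are shown below. What is called first, only, known or untested is meant among the compounds shown, and "the series" means these compounds.

Compound 1 `CC(=O)Oc1ccc(-n2c(-c3ccccc3)cc3c2CCCC3)cc1C(=O)O` gives 50% in a functional assay on the whole organism (strain Wistar) for inhibition, with Rattus norvegicus as the target, read by paw edema, with stated times of 30 min and 3 h, at a dose of 200 mg/kg by the oral route; on this read-out higher numbers stand for more inhibition at the one dose given (going by the name of the read-out) and lower numbers for less inhibition.
Compound 2 `COc1cccc(-c2cc3c(n2-c2ccc(O)c(C(=O)O)c2)CCCC3)c1` gives 20% in this assay.
Compound 3 `O=C(O)c1cc(-n2c(-c3ccc(F)cc3)cc3c2CCCC3)ccc1O` gives >= 60% in this assay.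

The value of compound 3 is a limit of this assay rather than an exact number, as noted in the limit of >= 60% in this assay, at which 1 of the 3 values shown sits. Compound 3 therefore stands at the top of the three values shown, and compound 2 stands lowest, with compound 1 in between.

Compound 4 `O=C(O)c1cc(-n2c(-c3cccs3)cc3c2CCCC3)ccc1O` differs from compound 3 in one place: thiophen-2-yl in place of 4-fluorophenyl on an aromatic carbon. Among the compounds with values here, the only measured step at this position is a number at least 40 percentage points higher from compound 2 to compound 3 (beyond the scatter), which shows that exchanging the group here can move the read-out strongly. That step concerns different groups from the present change, so it sets the scale of what a swap at this position can do without fixing its direction. Within the data shown here, no measured pair shows thiophen-2-yl.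

Given that compound 3 sits at a limit and the new group is untested, compound 4 is estimated to give 50%, with a range from 25% to 70%. This corresponds to an expected step of a number at least 10 percentage points lower from compound 3 to compound 4 (that floor lies within the scatter).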

Compound 4, a percentage reported as inhibition, in the whole organism at one dose (the size of the read-out at that dose, not a potency): 30%
Estimate against measurement, compound 4: 20 percentage points above; the measured number falls inside the stated range.
By their numbers in this assay, from the lowest: compounds 2 and 4 (each within the scatter of the next); then compound 1. At a limit, above all of these: compound 3.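

Thiophen-2-yl does not keep the read-out of 4-fluorophenyl on this aromatic carbon of the shared core: in this assay, the exchange gives a number at least 30 percentage points lower from compound 3 to compound 4 (beyond the scatter). As far as these compounds go, compound 3 stands at a limit of the assay rather than at an exact number, so the full size of this step stays unknown: the limit of >= 60% in this assay, at which 1 of the 4 values shown sits. Set against 3-methoxyphenyl, thiophen-2-yl gives a number 10 percentage points higher from compound 2 to compound 4 (within the scatter), so among the three groups compared at this place, only 4-fluorophenyl stands apart.

The compounds shown leave open how this assay would respond to a phenyl ring carrying chlorine or a methyl group where 4-fluorophenyl has its fluorine, or to a pyridin-3-yl ring at this place, and so whether the fluorine or the six-membered ring matters here. Compound 1 differs from each of the other compounds in more than one place, which leaves the separate contributions of its acetyl group and its unsubstituted phenyl ring open as well.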